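The source may hold more compounds than are shown below. What is called first, only, known or untested is meant among the compounds shown, and "the series" means these compounds.

Working notes on the series.

Compound 1 `COc1ccc(-c2cc(C(=O)Nc3nc4ccc(F)cc4s3)nc3cc(-c4ccccc4)nn23)cc1` gives 11700 nM in a functional assay on A549 cells (Homo sapiens) for cytotoxicity, read by MTT assay, with a stated time of 48 h; a lower number here means a stronger inhibitor, a higher number a weaker inhibitor. Compound 2 `COc1ccc(-c2cc(C(=O)Nc3nc4ccc(F)cc4s3)nc3cc(-c4ccccc4)nn23)cc1OC` carries the change methoxy in place of hydrogen on an aromatic carbon relative to compound 1, and in this assay compound 2 gives 6910 nM; the step is a 1.7-fold lower number from compound 1 to compound 2 (0.23 log units; within the scatter). Compound 3 `COc1ccc(-c2cc(C(=O)Nc3nc4cc(C)c(C)cc4s3)nc3cc(-c4ccccc4)nn23)cc1OC` gives 2950 nM in this assay, the step being a 2.3-fold lower number from compound 2 to compound 3 (0.37 log units; beyond the scatter). The difference between the cores of compound 1 and compound 3 is not broken down here.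

Compound 4 `COc1cc(-c2cc(C(=O)Nc3nc4cc(C)c(C)cc4s3)nc3cc(-c4ccccc4)nn23)cc(OC)c1OC` is not yet measured. Its difference from compound 3 is methoxy in place of hydrogen on an aromatic carbon. This is the same kind of change as the one from compound 1 to compound 2, with the distinction that in compound 4 the entering methoxy is also meta to a methoxy group, which is not the case in compound 2; the same kind of change occurs twice among these compounds.

From the earlier step, which was within the scatter, a small downward move is expected: the estimated step is a 1.5-fold lower number from compound 3 to compound 4 (0.17 log units; within the scatter), resting on a 1.7-fold lower number from compound 1 to compound 2 (0.23 log units; within the scatter). Compound 4 is therefore expected to give about 2000 nM in this assay, with a likely range from 900 nM to 4500 nM.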

Compound 4, half-maximal inhibitory concentration: 2340 nM
Estimate against measurement, compound 4: 1.2-fold (0.07 log units) below, and the stated range covers the measured number.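

In this assay the new step is a 1.3-fold lower number from compound 3 to compound 4 (0.10 log units; within the scatter) and so shows no change that can be told from the scatter, whether the ring goes from 3,4-dimethoxyphenyl to 3,4,5-trimethoxyphenyl or not. This does not show that methoxy lowers the number on either core, since neither step stands clear of the scatter, and two pairs cannot establish a rule for the series, least of all as the entering methoxy in compound 4 is also meta to a methoxy group, unlike that in compound 2. What can be said is that the change carries across these two cores with the same small size, and no difference between the cores appears: the same change on two cores in this assay, a 1.7-fold lower number (0.23 log units; within the scatter) from compound 1 to compound 2 and a 1.3-fold lower number (0.10 log units; within the scatter) from compound 3 to compound 4, 1.3-fold (0.13 log units) apart, within the scatter of two such steps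

Open, going by these compounds, is whether a hydroxy group, an amine or a longer chain such as ethoxy at the same place on the ring would give a step beyond the scatter. Also open, on these data alone, is whether the same small step would hold on a core other than these two.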